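A few compounds are considered here, and "the series" means these few. Any claim that something is new, unique, unknown or untested is made for them only; others in the source may bear on it.

The compounds with a measured value:
compound 2 `CC(C(=O)NCc1ccc(Cl)cc1)N1C(=O)CCC1=O`: 43.6 mg/kg
compound 3 `CC(C(=O)NCc1ccc(C(F)(F)F)cc1)N1C(=O)CCC1=O`: 54.5 mg/kg

Compound 1 `CC(C(=O)NCc1ccccc1Cl)N1C(=O)CCC1=O` is the parent of this account, but in a functional assay on the whole organism (strain Albino Swiss CD1) with Mus musculus as the target (on this read-out higher numbers stand for an effect only at larger amounts of compound and lower numbers for an effect already at smaller amounts), compound 1 gives "not determined" (no result reported), that is, no result was reported for compound 1, so it stands nowhere on the numbers shown. Among the compounds with values here, its two relatives give the only scale: in this assay compound 2 gives 43.6 mg/kg and compound 3 gives 54.5 mg/kg, and the single measured step, a 1.3-fold higher number from compound 2 to compound 3 (0.10 log units; within the scatter), is within the scatter, so the two are not distinguishable.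

Compound 4 `CCC(C(=O)NCc1ccccc1Cl)N1C(=O)CCC1=O` differs from compound 1 by methyl in place of hydrogen on a saturated chain carbon, two bonds along the chain from an amide-type nitrogen in a ring and a carbonyl carbon. Within the data shown here, none of the measured compounds differ from one another at that place, so no measured step bears on this change; the one step known concerns a substituent on the aromatic ring. Among the measured compounds shown here, what can be said is only that the change is small in count, and that both measured relatives of the shared core fall close together in this assay.

The expectation for compound 4 therefore rests on compound 2 with 43.6 mg/kg and on compound 3 with 54.5 mg/kg as the anchor, with a wide range to admit an unknown effect of the change. Compound 4 is estimated to give 50 mg/kg in this assay, expected between 20 mg/kg and 130 mg/kg.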

Compound 4, dose for half-maximal effect: 76.4 mg/kg
Compound 4: the middle estimate sits 1.5-fold (0.18 log units) below what was measured; the measured number falls inside the stated range.
By their numbers in this assay, from the lowest: compounds 2, 3 and 4 (each within the scatter of the next).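

Within the data shown here, the pair compound 1 and compound 4 cannot be read as a step in this assay, so the value of compound 4 adds no new step. Nothing shown offers an explanation for that value. The compounds shown leave open what methyl in place of hydrogen on that saturated chain carbon does by itself in this assay.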